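A few compounds are considered here, and "the series" means these few. Any claim that something is new, unique, unknown or untested is made for them only; others in the source may bear on it.

Measured compounds:
- compound 1, `Cc1ccc(CN2CCc3cc(NC(=O)NCc4ccncc4)ccc32)cc1`: "not determined" (no result reported)
- compound 2, `CC(C)(C)OC(=O)N1CCC(c2nc3ccc(NC(=O)NCc4ccncc4)cn3n2)CC1`: 29%
- compound 3, `Cc1ccc(C(=O)n2ccc3cc(NC(=O)NCc4ccncc4)ccc32)cc1`: 76%

Compound 1 was run in an assay on HEK293-A cells for activation of Nicotinamide phosphoribosyltransferase (Homo sapiens), tested at 3 uM (on this read-out lower numbers stand for a weaker effect and higher numbers for a stronger effect at the one concentration tested), but no result was reported for it, so it stands without a number of its own. Within the data shown here, of the two compounds with values, compound 2 gives 29% in this assay and compound 3 gives 76% in this assay; the two have different cores and no single structural step connects them, so their values are simply taken as they stand.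

The untested compound 4, `Cc1ccc(C(=O)N2CCc3cc(NC(=O)NCc4ccncc4)ccc32)cc1`, keeps the shared core of compound 1 and differs from it in one place: (4-methylphenyl)carbonyl in place of 4-methylbenzyl on a nitrogen on an aromatic ring in a ring. Compound 1 has no number. Among the measured compounds shown here, no step in this assay can be computed for this change, and the expected size of the step is not stated. What can be said is that compound 3 carries the same (4-methylphenyl)carbonyl on a closely related core and gives 76% in this assay, which places compound 4 near the stronger end of what has been seen.

Compound 4 is therefore estimated to give 60% in this assay, with an expected range from 30% to 85%.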

Compound 4, a percentage reported as activity, at one concentration (the size of the read-out at that concentration, not a potency): 45%
Compound 4: middle estimate off by 15 percentage points, on the high side; low and high end bracket the measured number.
By their numbers in this assay, from the lowest: compound 2; then compound 4; then compound 3.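

No step can be read between compound 1 and compound 4 in this assay: compound 1 has no number there. Nothing available bears on the result for compound 4. The compounds shown leave open how (4-methylphenyl)carbonyl in place of 4-methylbenzyl on the shared core changes the read-out in this assay.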